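Isomeric bicyclic variants on the lactam nitrogen, factor X

This account rests on a few compounds, and the source may have more. Where it says the series, first, only, none or still open, it means among the compounds named here.

Measured so far:
- compound 1 `O=C1[C@@H](NS(=O)(=O)c2nc3cc(Cl)ccc3[nH]2)CCN1Cc1cc2cc[nH]cc-2n1`: 21%
- compound 2 `O=C1[C@@H](NS(=O)(=O)c2cc3cccnc3s2)CCN1Cc1cc2[nH]cccc-2n1`: 44%
- compound 3 `O=C1[C@@H](NS(=O)(=O)c2nc3cc(Cl)ccc3[nH]2)CCN1Cc1cc2c[nH]ccc-2n1`: 31%

All three share the lactam core with a sulfonamide on one side and a methylene-linked bicyclic group on the ring nitrogen. In an assay on isolated protein for inhibition of coagulation factor X (Oryctolagus cuniculus), tested at 1 uM (on this read-out higher numbers stand for more inhibition at the one concentration tested (going by the name of the read-out) and lower numbers for less inhibition), compound 3 gives 31%, the second highest of the three numbers; compound 1 lies nearest, and compound 2 lies furthest with a number beyond the scatter above it.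

The next compound is compound 4 `O=C1[C@@H](NS(=O)(=O)c2nc3cc(Cl)ccc3[nH]2)CCN1Cc1cc2[nH]cccc-2n1`, which has the same atoms as compound 3 joined differently: a group of 9 heavy atoms (7 carbon, 2 nitrogen; one five-membered aromatic ring with 1 hetero atom, one six-membered aromatic ring with 1 hetero atom) in place of a group of 9 heavy atoms (7 carbon, 2 nitrogen; one five-membered aromatic ring with 1 hetero atom, one six-membered aromatic ring with 1 hetero atom), on a saturated chain carbon bound to an amide-type nitrogen in a ring.

For the measured compounds named here, one measured step bears on this kind of change. It is a number 10 percentage points higher from compound 1 to compound 3 (within the scatter), the same sort of rearrangement of the bicyclic group, and it stayed within the scatter. The bicyclic group that compound 4 receives is already present in compound 2, but paired there with a different sulfonyl aryl. In this assay compound 2 gives 44%, which only shows that this group is compatible with a number in the upper part of the set.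

On that basis a step from compound 3 to compound 4 of a number 4 percentage points higher from compound 3 to compound 4 (within the scatter) is expected, not beyond the scatter. Compound 4 is estimated at 35%, with a range from 15% to 55%.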

Compound 4, a percentage reported as inhibition, at one concentration (the size of the read-out at that concentration, not a potency): 14%
Estimate against measurement, compound 4: 21 percentage points above; measured number outside the range, below it.
By their numbers in this assay, from the lowest: compounds 4, 1 and 3 (each within the scatter of the next, the first and the last beyond it); then compound 2.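

In this assay, the place on a saturated chain carbon bound to an amide-type nitrogen in a ring proves sensitive to how the bicyclic group is joined: the step is a number 17 percentage points lower from compound 3 to compound 4 (beyond the scatter), although the atoms and the counted hydrogen-bond donor and acceptor stay the same. Not every such rearrangement separates the compounds, since the step is a number 7 percentage points lower from compound 1 to compound 4 (within the scatter), so only the pair of compound 3 and compound 4 shows this sensitivity, while the group on the sulfonyl sulfur also matters: with the same bicyclic group on both compounds, the change of that group gives a number 30 percentage points lower from compound 2 to compound 4 (beyond the scatter), and the higher number of compound 2 therefore does not carry over to the chlorinated sulfonyl partner. Nothing available gives a reason for either step.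

As far as these compounds go, it remains open whether the isomeric bicyclic groups would fall in the same order when paired with the sulfonyl group of compound 2, as all the isomer comparisons here rest on the chlorinated partner. Also open, from the compounds shown here alone, is how a plain phenyl ring or a primary amine would compare with these bicyclic groups at the same place.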